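A few compounds are considered here, and "the series" means these few. Any claim that something is new, unique, unknown or untested is made for them only; others in the source may bear on it.

Compound 1 `O=S(=O)(Nc1ncccn1)c1ccc(Nc2nncc3ccccc23)cc1`: 23 nM
Compound 2 `COc1ccc(NC(=S)NNc2nncc3ccccc23)cc1`: 47 nM
Compound 3 `O=C1CS/C(=N/Nc2nncc3ccccc23)N1`: 25 nM

These three compounds were measured in a functional assay on UO-31 cells (Homo sapiens) for antiproliferative activity, read by sulforhodamine B assay, with a stated time of 72 h; a higher number here means a weaker inhibitor, a lower number a stronger inhibitor. Compound 1, at 23 nM, shares the low end of this small set with compound 3, at 25 nM, and the two lie within the scatter of each other. Compound 2, at 47 nM, carries a higher number, and its gap to compound 1 lies beyond the scatter.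

The next compound to be tested is compound 4 `O=S(=O)(Nc1ccccn1)c1ccc(Nc2nncc3ccccc23)cc1`. It keeps the core of compound 1 and makes one swap: pyridin-2-yl in place of pyrimidin-2-yl on a sulfonamide nitrogen, (pyridin-2-yl in place of pyrimidin-2-yl on a sulfonamide nitrogen).

For the measured compounds named here, no two measured compounds differ in just one place, so the data offer no direct guide to the size of such a step. The expectation therefore starts from compound 1 at 23 nM. It also draws on the closeness of the three numbers, even though compound 2 and compound 3 carry quite different groups on the shared core. In this assay, no change beyond the scatter is expected, and no firm direction can be given. The expected step is small, a 1.3-fold higher number from compound 1 to compound 4 (0.12 log units; within the scatter). For compound 4, the estimated value is 30 nM, with an expected range from 12 nM to 80 nM.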

Compound 4, half-maximal inhibitory concentration: 44 nM
For compound 4 the middle estimate is 1.5-fold (0.17 log units) below the measured one; measured number inside the range.
By their numbers in this assay, from the lowest: compounds 1, 3, 4 and 2 (each within the scatter of the next, the first and the last beyond it).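

For the compounds shown here, compound 1 and compound 4 are the only pair here that differ in one place, so they give the sole direct reading of a change on the sulfonamide nitrogen: in this assay, the step is a 1.9-fold higher number from compound 1 to compound 4 (0.28 log units; within the scatter) for pyridin-2-yl in place of pyrimidin-2-yl. The incoming ring has the same 6 heavy atoms and remains a six-membered aromatic ring, but it has 1 hetero atom rather than 2 and 1 hydrogen-bond acceptor rather than 2. At this position, that exchange gives a difference that stays inside the usual scatter of repeated measurements, so this pair shows no clear separation between the two rings. No supporting measurement bears on why the two compounds compare in this way.

The compounds shown leave open how a ring with no hetero atom, such as phenyl, or a small group such as methyl or acetyl, would read on this sulfonamide nitrogen. They also leave open what would happen with the ring removed altogether, leaving the bare sulfonamide amine.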